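Swapping a Chlorophenyl for a Hydroxyphenyl on a Shared Core

The source may report more compounds than this note shows. Statements on the series, on what has been measured and on what is new or still open speak of the compounds shown alone.

Compound 1 `COc1cccc(/C=C2\CCC/C(=C\c3cc(Cl)cc(Cl)c3)C2=O)c1OC`: 6100 nM
Compound 2 `COc1ccc(/C=C2\CCC/C(=C\c3ccccc3Cl)C2=O)cc1OC`: 6800 nM

In a functional assay on HT-1080 cells (Homo sapiens) for cytotoxicity, read by MTT assay, with a stated time of 72 h (on this read-out higher numbers stand for weaker inhibition and lower numbers for stronger inhibition), compound 2 gives 6800 nM, the larger of the two numbers, yet its gap to compound 1 lies within the scatter. Compound 3 `COc1ccc(/C=C2\CCC/C(=C\c3cccc(O)c3)C2=O)cc1OC` has not been measured; it differs from compound 2 by 3-hydroxyphenyl in place of 2-chlorophenyl on a double-bonded chain carbon bound to a double-bonded ring carbon. Among the measured compounds shown here, no step between measured compounds is available, so the size of this change cannot be read from the numbers. Compound 3 is expected to shift by a 1.0-fold higher number from compound 2 to compound 3 (0.01 log units; within the scatter), no further than the scatter allows. Compound 3 is estimated at 7000 nM, within 2500 nM to 20000 nM.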

Compound 3, half-maximal inhibitory concentration: 1700 nM
For compound 3 the middle estimate is 4.1-fold (0.61 log units) above the measured one, and the stated range ends above it.
By their numbers in this assay, from the lowest: compound 3; then compounds 1 and 2 (each within the scatter of the next).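

On the double-bonded chain carbon bound to a double-bonded ring carbon, 3-hydroxyphenyl in place of 2-chlorophenyl gives a 4.0-fold lower number from compound 2 to compound 3 (0.60 log units; beyond the scatter) in this assay. Among the compounds shown here, compound 1 and compound 2 differ in more than one place, so this is the first single change showing that the group held here can move the number beyond the scatter. Nothing at hand explains this step.

The compounds shown leave open whether the step follows the loss of the chlorine or the arrival of the hydroxyl. Going by these compounds, how a 3-aminophenyl or 3-methoxyphenyl group would fare in this place also remains open.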